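Amide variation on a shared core, then a methyl probe

A few compounds are considered here, and "the series" means these few. Any claim that something is new, unique, unknown or untested is made for them only; others in the source may bear on it.

Measured so far, in a functional assay on A375P cells (Homo sapiens) for antiproliferative activity, read by MTT assay, with a stated time of 48 h; on this read-out lower numbers stand for stronger inhibition and higher numbers for weaker inhibition:
Compound 1 `CC(=O)Nc1cccc2c(-c3cccc(NC(=O)c4ccc(C)c(C)c4)c3)ccnc12` gives > 20000 nM; this value is a limit of the assay, not a number.
Compound 2 `CC(=O)Nc1cccc2c(-c3cccc(NC(=O)c4ccc(Cl)c(C(F)(F)F)c4)c3)ccnc12` gives 2400 nM.
Compound 3 `CC(=O)Nc1cccc2c(-c3cccc(NC(=O)c4cc5ccccc5s4)c3)ccnc12` gives 9100 nM.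

Compound 2 has the lowest of the two numbers reported; compound 3 sits nearest to it, and the step of a 3.8-fold higher number from compound 2 to compound 3 (0.58 log units; beyond the scatter) lies beyond the scatter. Compound 1 contributes only a limit (the limit of > 20000 nM in this assay, at which 1 of the 3 values shown sits), so the steps of an at least 8.3-fold lower number from compound 1 to compound 2 (0.92 log units; beyond the scatter) and an at least 2.1-fold lower number from compound 1 to compound 3 (0.34 log units; beyond the scatter) are known only as minimum sizes.

Compound 4 `CC(=O)Nc1cccc2c(-c3cc(NC(=O)c4ccc(Cl)c(C(F)(F)F)c4)ccc3C)ccnc12` differs from compound 2 by methyl in place of hydrogen on an aromatic carbon. None of the three measured steps touches this position: all of them exchange the aryl group on the carbonyl carbon, whereas the amide of compound 2 is kept unchanged in compound 4. Within the data shown here, no step therefore bears directly on the methyl, and there is no basis for expecting a step beyond the scatter in either direction.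

The number for compound 4 in this assay is expected to be 2600 nM, with a range from 800 nM to 9000 nM. The expected step of a 1.1-fold higher number from compound 2 to compound 4 (0.03 log units; within the scatter) is thus estimated to stay within the scatter, with the range left wide to allow for either outcome.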

Compound 4, half-maximal inhibitory concentration: 12200 nM
Compound 4: the middle estimate sits 4.7-fold (0.67 log units) below what was measured, outside the stated range (above it).
By their numbers in this assay, from the lowest: compound 2; then compounds 3 and 4 (each within the scatter of the next). At a limit, above all of these: compound 1.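

Notes on the methyl position: in this assay, the step of a 5.1-fold higher number from compound 2 to compound 4 (0.71 log units; beyond the scatter) is the first in the series that leaves the aryl group on the carbonyl carbon untouched, and it shows that the number also responds to a change on the other side of the amide. A single added carbon on an aromatic carbon, ortho to a large group and para to a large group, is enough to carry the number beyond the scatter, so this position cannot be treated as indifferent to substitution. The step is of the same modest class as a 3.8-fold higher number from compound 2 to compound 3 (0.58 log units; beyond the scatter), which exchanges a whole aryl group, but nothing shown accounts for the change produced by the methyl.

As far as these compounds go, how a methoxy group, an amine or a longer chain on this same carbon would compare with hydrogen and methyl remains open. Also open, from the compounds shown here alone, is whether the methyl step carries over when 1-benzothiophen-2-yl or 3,4-dimethylphenyl stands on the carbonyl carbon in place of 4-chloro-3-(trifluoromethyl)phenyl.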